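The source may report more compounds than this note shows. Statements on the series, on what has been measured and on what is new or still open speak of the compounds shown alone.

The study compares three measured compounds and one still untested in a functional assay on NCI-H226 cells (Homo sapiens) for inhibition, read by MTT assay, with a stated time of 48 h, tested at 10 uM; on this read-out lower numbers stand for less inhibition and higher numbers for more inhibition at the one concentration tested (going by the name of the read-out). Compound 1 `COc1cc(NC(=O)Nc2cc(Nc3cccc(C(C)(C)C)c3)ncn2)cc(OC)c1` gives 40% in this assay. Compound 3 `COc1cc(NC(=O)Nc2cc(Nc3cc(Br)ccc3OC)ncn2)cc(OC)c1` gives 42.7% in this assay, and compound 2 `COc1ccc(Br)cc1Nc1cc(NC(=O)Nc2c(Cl)cccc2Cl)ncn1` gives 33% in this assay.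

Compound 1 and compound 3 share the same core and differ only in the group on a nitrogen on an aromatic ring: 3-(tert-butyl)phenyl in place of 5-bromo-2-methoxyphenyl on a nitrogen on an aromatic ring. The matching step, a number 2.7 percentage points higher from compound 1 to compound 3 (within the scatter), stays within the scatter, so the two are read as alike. Compound 3 and compound 2 differ in the group on an amide-type nitrogen: 2,6-dichlorophenyl in place of 3,5-dimethoxyphenyl on an amide-type nitrogen. That step, a number 9.7 percentage points lower from compound 3 to compound 2 (within the scatter), also stays within the scatter.

Compound 4 `CC(C)(C)c1cccc(Nc2cc(NC(=O)Nc3c(Cl)cccc3Cl)ncn2)c1` is not yet measured in this assay. It differs from compound 1 by the same change that turned compound 3 into compound 2: 2,6-dichlorophenyl in place of 3,5-dimethoxyphenyl on an amide-type nitrogen. The place is described in the same words in both cases, so the change is the same. Because that change made a number 9.7 percentage points lower from compound 3 to compound 2 (within the scatter), the step for compound 4 is expected to be of similar size, a number 9 percentage points lower from compound 1 to compound 4 (within the scatter). On that footing compound 4 is estimated at 31% in this assay, with the result expected to fall between 17% and 45%. Whether this expectation holds is what the measurement that follows will show.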

Compound 4, a percentage reported as inhibition, at one concentration (the size of the read-out at that concentration, not a potency): 36.5%
The estimate for compound 4 lay 5.5 percentage points below the measured number; low and high end bracket the measured number.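

On the core carrying 3-(tert-butyl)phenyl, putting 2,6-dichlorophenyl in place of 3,5-dimethoxyphenyl on an amide-type nitrogen gave, in this assay, a number 3.5 percentage points lower from compound 1 to compound 4 (within the scatter). Set beside the same change on the core carrying 5-bromo-2-methoxyphenyl, the two steps do not differ: the same change on two cores in this assay, a number 9.7 percentage points lower (within the scatter) from compound 3 to compound 2 and a number 3.5 percentage points lower (within the scatter) from compound 1 to compound 4, 6.2 percentage points apart, within the scatter of two such steps This shows that the change carried from one core to the other in this small set without a step beyond the scatter, but neither step stands clear of the scatter, so the pair shows neither a real effect of the change nor a shared size for it, and two cores say nothing about other cores in the series.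

The compounds shown leave open how an amine, a carboxylic acid or a longer alkyl chain would behave in place of the 3,5-dimethoxyphenyl or 2,6-dichlorophenyl group on the amide-type nitrogen, and whether such a group would give a step beyond the scatter in this assay. They also leave open whether the two steps would still agree at other concentrations, as each number here is the size of the read-out at a single concentration and not a potency.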